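The source may hold more compounds than are shown below. What is called first, only, known or untested is meant among the compounds shown, and "the series" means these compounds.

Of the compounds shown here, two from the series have been measured so far in a physicochemical assay for lipophilicity, read by HPLC, measured as octanol-water partition; on this read-out higher numbers stand for higher lipophilicity and lower numbers for lower lipophilicity. Compound 1 `CN1CCN(C[C@H]2CN(c3ccc(-n4cc(-c5ccccn5)cn4)c(F)c3)C(=O)O2)CC1` gives 2.2, and compound 2 `CS(=O)(=O)NC[C@H]1CN(c2ccc(-n3cc(-c4ccccn4)cn3)c(F)c2)C(=O)O1` gives 1.38. Among the measured compounds shown here, the single step known, a number 0.82 log units lower from compound 1 to compound 2 (beyond the scatter), shows that replacing the 4-methylpiperazin-1-yl group with methanesulfonamido lowered the read-out beyond the scatter, leaving compound 2 as the lowest of the two numbers.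

Compound 3 `COC(=O)NC[C@H]1CN(c2ccc(-n3cc(-c4ccccn4)cn3)c(F)c2)C(=O)O1` is not yet measured. It differs from compound 2 in one place: methoxycarbonyl in place of methylsulfonyl on an amine nitrogen. For the measured compounds named here, no measured step involves this pair of groups, so the earlier step only sets the scale of what one side-chain change can do here. Since the methylsulfonyl group leaves and a methoxycarbonyl group enters, a modest rise in this assay is expected, so that compound 3 is estimated at 1.85, within a range of 1.45 to 2.3. That estimate corresponds to an expected step of a number 0.47 log units higher from compound 2 to compound 3 (beyond the scatter).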

Compound 3, partition coefficient: 2.03
Compound 3: the middle estimate sits 0.18 log units below what was measured, within the range that was stated.
By their numbers in this assay, from the lowest: compound 2; then compounds 3 and 1 (each within the scatter of the next).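

Swapping methylsulfonyl for methoxycarbonyl on an amine nitrogen changes the number in this assay (a number 0.65 log units higher from compound 2 to compound 3 (beyond the scatter)), even though the two groups have the same count of heavy atoms and of hydrogen-bond acceptors, so those counts alone do not settle the read-out at this place. The (methoxycarbonyl)amino group also brings the number back close to that of the 4-methylpiperazin-1-yl group (a number 0.17 log units lower from compound 1 to compound 3 (within the scatter)), so of the two groups on the amine nitrogen, only methanesulfonamido stands clearly apart from 4-methylpiperazin-1-yl. Nothing available explains why these two groups on the amine nitrogen differ.

Still open, as far as these compounds go, is where an acetyl group, or a longer ethoxycarbonyl chain, would fall on the same amine nitrogen. Also open, from the compounds shown here alone, is how a free amine or a carboxylic acid on the saturated chain carbon would compare.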